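Swapping the aryl on the chain carbon in a styryl thioether series

This account rests on a few compounds, and the source may have more. Where it says the series, first, only, none or still open, it means among the compounds named here.

Compound 2, `O=C(/C(=C\c1ccc(Cl)cc1Cl)Sc1ccc(Br)cc1)c1ccc(Br)cc1`, is assayed in a functional assay on DU-145 cells (Homo sapiens) for inhibition, read by trypan blue exclusion, with a stated time of 96 h (on this read-out lower numbers stand for stronger inhibition of growth and higher numbers for weaker inhibition of growth), and gives 1000 nM. It stands level with compound 1, `O=C(/C(=C\c1ccc(F)cc1F)Sc1ccc(Br)cc1)c1ccc(Br)cc1`, which in this assay gives 1000 nM; the step of no change at the digits printed from compound 1 to compound 2 (within the scatter) lies within the scatter of repeated measurements. Compound 3, `COc1ccc(/C=C(/Sc2ccc(Br)cc2)C(=O)c2ccc(Br)cc2)c(F)c1`, differs from compound 2 in one place: 2-fluoro-4-methoxyphenyl in place of 2,4-dichlorophenyl on a double-bonded chain carbon bound to a double-bonded chain carbon. Going by the values given here, the only measured step that bears on this change is the exchange of one aryl for another at the same place, and that step, no change at the digits printed from compound 1 to compound 2 (within the scatter), produced no movement beyond the scatter. With nothing in the data to suggest that a third aryl at this place behaves differently, the expected step of no change at the digits printed from compound 2 to compound 3 (within the scatter) is none beyond the scatter. Compound 3 is therefore estimated to give 1000 nM in this assay, with a range of 400 nM to 3000 nM.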

Compound 3, concentration for 50% growth inhibition: 20000 nM
The estimate for compound 3 lay 20-fold (1.30 log units) below the measured number; the whole stated range lies below it.
By their numbers in this assay, from the lowest: compounds 1 and 2 (each within the scatter of the next); then compound 3.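

In this assay this position proved less tolerant than the two dihalophenyl compounds had suggested: the aryl on the chain carbon cannot be exchanged freely, and the move to 2-fluoro-4-methoxyphenyl brings a 20-fold higher number from compound 2 to compound 3 (1.30 log units; beyond the scatter) where the earlier exchange had brought no movement beyond the scatter. The comparison with the difluoro compound narrows the change to a single group, as methoxy in place of fluoro on an aromatic carbon brings a 20-fold higher number from compound 1 to compound 3 (1.30 log units; beyond the scatter) while the other fluoro stays. Growth inhibition thus stayed level across the two halogen pairs and weakened sharply once methoxy entered.

On these data alone, whether this loss belongs to methoxy itself or would follow any group other than a halogen stays open, and a methyl, a hydroxyl or an amine on that aromatic carbon would separate the two. The data offer no explanation for the size of this step.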